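Adding a Methoxy Group: What to Expect for Compound 4

The source may hold more compounds than are shown below. What is called first, only, known or untested is meant among the compounds shown, and "the series" means these compounds.

The measured compounds are:
compound 1, `COc1ccc(/C=C2\CCC/C(=C\c3cccc(OC)c3OC)C2=O)cc1OC`, which gives 6400 nM in a functional assay on HT-1080 cells (Homo sapiens) for cytotoxicity, read by MTT assay, with a stated time of 72 h; a higher number here means a weaker inhibitor, a lower number a stronger inhibitor;
compound 2, `COc1cccc(/C=C2\CCC/C(=C\c3ccc(OC)c(OC)c3)C2=O)c1`, which gives 4600 nM in this assay;
compound 3, `COc1ccc(/C=C2\CCC/C(=C\c3ccc(OC)c(OC)c3)C2=O)cc1`, which gives 7200 nM in this assay.

All three numbers lie within the usual scatter of one another, so none of these compounds can be called stronger or weaker than the others. Compound 2 and compound 3 differ in their cores: 4-methoxyphenyl in place of 3-methoxyphenyl on a double-bonded chain carbon bound to a double-bonded ring carbon. The step of a 1.6-fold higher number from compound 2 to compound 3 (0.19 log units; within the scatter). Compound 1 differs from compound 2 by one change, (methoxy in place of hydrogen on an aromatic carbon), and the step of a 1.4-fold higher number from compound 2 to compound 1 (0.14 log units; within the scatter).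

Compound 4, `COc1ccc(/C=C2\CCC/C(=C\c3ccc(OC)c(OC)c3)C2=O)c(OC)c1`, has not yet been measured in this assay. It differs from compound 3 by methoxy in place of hydrogen on an aromatic carbon. Going by the values given here, this is the same kind of change as the one from compound 2 to compound 1, though not the same: in compound 1 the entering methoxy sits ortho to a methoxy group, while in compound 4 it sits meta to a methoxy group.

The expectation for compound 4 rests on compound 1 and compound 2, whose step a 1.4-fold higher number from compound 2 to compound 1 (0.14 log units; within the scatter) stayed within the scatter. The estimated step is therefore a 1.2-fold higher number from compound 3 to compound 4 (0.07 log units; within the scatter). Compound 4 is expected to give about 8500 nM in this assay, most likely between 4000 nM and 18000 nM.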

Compound 4, half-maximal inhibitory concentration: 17100 nM
For compound 4 the middle estimate is 2.0-fold (0.30 log units) below the measured one; low and high end bracket the measured number.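

In this assay, methoxy in place of hydrogen on an aromatic carbon gives a 2.4-fold higher number from compound 3 to compound 4 (0.38 log units; beyond the scatter), a modest step that makes compound 4 a weaker inhibitor than compound 3. Set beside the earlier case of the same change, this step cannot be told apart from it in size: the same change on two cores in this assay, a 1.4-fold higher number (0.14 log units; within the scatter) from compound 2 to compound 1 and a 2.4-fold higher number (0.38 log units; beyond the scatter) from compound 3 to compound 4, 1.7-fold (0.23 log units) apart, within the scatter of two such steps. The result therefore shows that, across these two cores, the size of the step does not measurably depend on the core, but it does not show that the change carries over reliably, since one step lies within the scatter and the other beyond it, the entering methoxy does not stand in the same surroundings on the two cores, and two cases are too few to support a rule for the series.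

The compounds shown carry only methoxy groups on their aromatic rings, so it remains open how a hydroxyl group, a fluorine atom, an amine or a longer chain such as ethoxy would behave in the place the new methoxy takes in compound 4, ortho to a large group and meta to a methoxy group. On these data alone, it also remains open whether the same change would give a step of similar size on any further core.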